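Thiocarbamate ring size step on the shared core

The compounds below may be only part of what the source reports. "The series", "measured", "known", "first", "only" and "open" are said of these compounds alone.

Measured compounds:
compound 1 `Cc1nc(S(C)(=O)=O)ccc1Oc1ncnc(OC2CCN(C(=O)OC(C)(C)C(F)(F)F)CC2)c1F` — in a functional assay on isolated protein for inhibition of Glucose-dependent insulinotropic receptor (Rattus norvegicus), read by HTRF and cAMP accumulation (on this read-out lower numbers stand for an effect already at smaller amounts and higher numbers for an effect only at larger amounts of compound), compound 1 gives 47.2 nM
compound 2 `Cc1nc(S(C)(=O)=O)ccc1Oc1ncnc(OC2CCN(C(=O)O[C@H](C)CF)CC2)c1F` — compound 2 gives 1520 nM
compound 3 `Cc1nc(S(C)(=O)=O)ccc1Oc1ncnc(OC2CCN(C(=O)SC3CC3)CC2)c1F` — compound 3 gives 126 nM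

Compound 3 stands second highest of the three numbers. Its nearest neighbour is compound 1, as a 2.7-fold higher number from compound 1 to compound 3 (0.43 log units; beyond the scatter) shows; its furthest is compound 2, as a 12-fold lower number from compound 2 to compound 3 (1.08 log units; beyond the scatter) shows. Both of these steps exchange the whole group on the carbonyl carbon, and they run in opposite directions, the larger fluorinated group giving the lower number and the smaller one the higher.

Compound 4 `Cc1nc(S(C)(=O)=O)ccc1Oc1ncnc(OC2CCN(C(=O)SC3CCC3)CC2)c1F` differs from compound 3 by cyclobutyl in place of cyclopropyl on a sulfur. Going by the values given here, no measured step changes a ring on the sulfur, so the two steps into compound 3 bear on it only loosely. The change is much smaller than either of those, so no step beyond the scatter is expected in this assay. Compound 4 is therefore expected at 100 nM, with a range from 40 nM to 250 nM, which means an expected step of a 1.3-fold lower number from compound 3 to compound 4 (0.10 log units; within the scatter).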

Compound 4, half-maximal effective concentration: 77.4 nM
For compound 4 the middle estimate is 1.3-fold (0.11 log units) above the measured one, within the range that was stated.
By their numbers in this assay, from the lowest: compounds 1, 4 and 3 (each within the scatter of the next, the first and the last beyond it); then compound 2.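

In this assay, cyclobutyl in place of cyclopropyl on a sulfur gives a 1.6-fold lower number from compound 3 to compound 4 (0.21 log units; within the scatter), so the two rings cannot be told apart at this position. Cyclobutylsulfanyl on the carbonyl carbon also cannot be told apart from 1-methyl-1-(trifluoromethyl)ethoxy, with a 1.6-fold higher number from compound 1 to compound 4 (0.21 log units; within the scatter), while the group carrying 1-(fluoromethyl)ethyl on an oxygen stays clearly separate, with a 20-fold lower number from compound 2 to compound 4 (1.29 log units; beyond the scatter). Nothing available explains these numbers.

From the compounds shown here alone, whether a cyclopentyl ring or an open chain such as isopropyl on the sulfur would stay in the same range remains open. Also open, going by these compounds, is whether an amine on the carbonyl carbon, in place of the sulfur-linked group, would match cyclobutylsulfanyl in this assay's read-out.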